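Amino substituent exchange on the shared core, cytotoxicity

The compounds below may be only part of what the source reports. "The series", "measured", "known", "first", "only" and "open" are said of these compounds alone.

Going by the values given here, compound 2 `O=C(Nc1ccc(NCc2ccc(O)cc2)cc1Cl)c1cc(Cl)ccc1O` gives 116000 nM in an ADME assay on A549 cells (Homo sapiens) for cytotoxicity, read by resazurin assay, with a stated time of 48 h (a lower number here means that less compound is tolerated, a higher number that more compound is tolerated), the highest of the two numbers so far; its nearest neighbour is compound 1 `CCN(CC)c1ccc(NC(=O)c2cc(Cl)ccc2O)c(Cl)c1` at 55500 nM, and the step of a 2.1-fold higher number from compound 1 to compound 2 (0.32 log units; beyond the scatter) is the only measured one. Compound 3 `CC(C)(CCO)Nc1ccc(NC(=O)c2cc(Cl)ccc2O)c(Cl)c1` differs from compound 2 by 3-hydroxy-1,1-dimethylpropyl in place of 4-hydroxybenzyl on a nitrogen on an aromatic ring. Among the compounds with values here, no measured step covers this exchange directly; the one step seen, changing the same amino group, was modest. For compound 3 the step of a 1.3-fold lower number from compound 2 to compound 3 (0.11 log units; within the scatter) is therefore expected to stay within the scatter, with no clear direction. Compound 3 is estimated at 90000 nM, between 40000 nM and 200000 nM.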

Compound 3, half-maximal cytotoxic concentration: 170000 nM
Beside the measured number, compound 3's estimate is 1.9-fold (0.28 log units) below it; low and high end bracket the measured number.
By their numbers in this assay, from the lowest: compound 1; then compounds 2 and 3 (each within the scatter of the next).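

In this assay the step of a 1.5-fold higher number from compound 2 to compound 3 (0.17 log units; within the scatter) shows that the open-chain 3-hydroxy-1,1-dimethylpropyl on the nitrogen and the ring-bearing 4-hydroxybenzyl cannot be told apart at this position. The step of a 3.1-fold higher number from compound 1 to compound 3 (0.49 log units; beyond the scatter) makes compound 3 the second compound with a hydroxyl-bearing amino group to stand beyond the scatter from compound 1. No evidence on the cause of these differences is available.

On these data alone, whether the hydroxyl matters for the gap to compound 1 stays open. A longer chain ending in a primary amine or a carboxylic acid is not among the compounds shown.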